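Replacing an anilide by a pyridinylmethyl ester

A few compounds are considered here, and "the series" means these few. Any claim that something is new, unique, unknown or untested is made for them only; others in the source may bear on it.

Three compounds share one core and differ only in the group attached to a carbonyl carbon on that core. In an assay on HL-60 cells for agonist activity at vitamin D3 receptor (Homo sapiens), read by microscopy, with a stated time of 96 h (on this read-out higher numbers stand for an effect only at larger amounts of compound and lower numbers for an effect already at smaller amounts), compound 1 `CC[C@@H](C)[C@H](NC(=O)c1ccc(C(CC)(CC)c2ccc(OCC(=O)C(C)(C)C)c(C)c2)n1CC)C(=O)OC` gives 590 nM. Compound 2 `CCOC(=O)CN(C)C(=O)c1ccc(C(CC)(CC)c2ccc(OCC(=O)C(C)(C)C)c(C)c2)n1CC` reaches only the limit of this assay, > 50000 nM. Compound 3 `CCn1c(C(=O)Nc2cccc(C(F)(F)F)c2)ccc1C(CC)(CC)c1ccc(OCC(=O)C(C)(C)C)c(C)c1` likewise reaches only the limit, > 50000 nM; this is where it stands, at the limit of > 50000 nM in this assay, at which 2 of the 3 values shown sit. The two measured steps that carry a number are an at least 84-fold higher number from compound 1 to compound 2 (1.92 log units; beyond the scatter) and an at least 84-fold higher number from compound 1 to compound 3 (1.92 log units; beyond the scatter). The step that the two limits leave unreadable from compound 2 to compound 3 gives no readable size.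

Compound 4 `CCn1c(C(=O)OCc2ccccn2)ccc1C(CC)(CC)c1ccc(OCC(=O)C(C)(C)C)c(C)c1` comes from compound 3 through the change ((pyridin-2-yl)methoxy in place of (3-(trifluoromethyl)phenyl)amino on a carbonyl carbon). Among the compounds with values here, no measured step covers this change; the only reading is that compound 1 alone shows activity, while both of its neighbours sit at the limit. Compound 4 is therefore expected to stay weak, its estimated step being an at least 2.5-fold lower number from compound 3 to compound 4 (0.39 log units; beyond the scatter) with most of that step unreadable. Compound 4 is estimated at 20000 nM, within a range from 1500 nM to 50000 nM, with a fair chance that only a limit is reported.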

Compound 4, half-maximal effective concentration: > 50000 nM
Compound 4: no number, only a limit; the forecaster's own chance of this, stated with the estimate: 60%; middle value at least 2.5-fold (0.39 log units) from the limit.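

In this assay compound 4 gives > 50000 nM, which is a limit of the assay and not a number. On the carbonyl carbon, putting (pyridin-2-yl)methoxy in place of the branched amino ester chain gives an at least 84-fold higher number from compound 1 to compound 4 (1.92 log units; beyond the scatter), so an ester link here, like the two other amide groups tried, does not bring back the activity of that chain. The steps among compound 2, compound 3 and compound 4 cannot be read, so these three cannot be ranked, and the picture is now one measured value against a shared limit: the limit of > 50000 nM in this assay, at which 3 of the 4 values shown sit.

On these data alone, it stays open whether a carboxylic acid in place of the methyl ester of compound 1 would keep any activity. As far as these compounds go, it also stays open whether an unbranched amino ester chain that keeps the amide hydrogen would do so.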